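The compounds below may be only part of what the source reports. "The series", "measured", "known", "first", "only" and "open" are said of these compounds alone.

Compound 1 `COc1ccccc1NC1=CC(=O)c2c(nc3n2[C@H]2OC[C@@H](O)[C@H]2OC3)C1=O`: 6580 nM
Compound 2 `O=C1C(N2CCCC2)=CC(=O)c2c1nc1n2[C@H]2OC[C@@H](O)[C@H]2OC1`: > 16000 nM

Both compounds were tested in a functional assay on MCF7 cells (Homo sapiens) for inhibition, read by sulforhodamine B assay; on this read-out lower numbers stand for stronger inhibition and higher numbers for weaker inhibition. Compound 2 gives > 16000 nM, which is a limit and not a number, so it stands at the limit of > 16000 nM in this assay, at which 1 of the 2 values shown sits. Compound 3 `O=C1C(N2CCCCC2)=CC(=O)c2c1nc1n2[C@H]2OC[C@@H](O)[C@H]2OC1` has piperidin-1-yl in place of pyrrolidin-1-yl on a double-bonded ring carbon. Going by the values given here, the only measured step that bears on this is an at least 2.4-fold higher number from compound 1 to compound 2 (0.38 log units; beyond the scatter). In that step, (2-methoxyphenyl)amino gave way to pyrrolidin-1-yl, whereas here one non-aromatic ring replaces another. Among the compounds with values here, no measured step shows such a ring swap, so no step beyond the scatter is expected in this assay, and another limit is quite possible. The estimated step is a step that the limit leaves unreadable from compound 2 to compound 3. For compound 3 the expected value is 18000 nM, with an estimated range from 7000 nM to 40000 nM.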

Compound 3, half-maximal inhibitory concentration: > 8000 nM
Compound 3: no number, only a limit; the forecaster's own chance of this, stated with the estimate: 60%; the middle value does not contradict the limit.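

In this assay compound 3 gives > 8000 nM, which is a limit and not a number. Piperidin-1-yl in place of (2-methoxyphenyl)amino on this double-bonded ring carbon gives an at least 1.2-fold higher number from compound 1 to compound 3 (0.08 log units; that floor lies within the scatter), so this step alone does not establish a loss of inhibition, whereas the change to pyrrolidin-1-yl, an at least 2.4-fold higher number from compound 1 to compound 2 (0.38 log units; beyond the scatter), goes beyond the scatter. The step between the two non-aromatic rings cannot be read, so neither compound can be ranked against the other.

From the compounds shown here alone, it remains open whether an open-chain amine such as dimethylamino at this place would give a real number in this assay rather than a limit. Going by these compounds, it is also open whether phenylamino, which lacks the methoxy group of compound 1, would hold a value near that of compound 1.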